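Cyclopropyl in place of pyridin-4-yl in the series

The compounds below may be only part of what the source reports. "The series", "measured", "known", "first", "only" and "open" are said of these compounds alone.

In an in vitro ADME assay on microsomes (Homo sapiens) for metabolic stability (a lower number here means that the compound disappears faster, a higher number that the compound lasts longer), compound 1 `O=C(Nc1ccc(-c2nc(N3CC4CCC(C3)O4)c3cnn(C4CCC5(CC4)OCCO5)c3n2)cc1)Nc1cccnc1` gives 0.217 h and compound 2 `O=C(Nc1ccncc1)Nc1ccc(-c2nc(N3CC4CCC(C3)O4)c3cnn(C4CCC5(CC4)OCCO5)c3n2)cc1` gives 0.217 h as well, which places compound 2 level with compound 1. Compound 3 `O=C(Nc1ccc(-c2nc(N3CC4CCC(C3)O4)c3cnn(C4CCC5(CC4)OCCO5)c3n2)cc1)NC1CC1` carries cyclopropyl in place of pyridin-4-yl on an amide-type nitrogen. Within the data shown here, one measured step bears on this: no change at the digits printed from compound 1 to compound 2 (within the scatter) for pyridin-4-yl in place of pyridin-3-yl. Among the measured compounds shown here, no measured step replaces an aromatic ring with a non-aromatic one, so this guide is weak. In this assay the expected 1.2-fold higher number from compound 2 to compound 3 (0.06 log units; within the scatter) stays within the scatter, with no direction favoured. Compound 3 is estimated at 0.25 h within a range from 0.13 h to 0.5 h on this evidence.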

Compound 3, half-life: 0.15 h
Beside the measured number, compound 3's estimate is 1.7-fold (0.22 log units) above it, and the stated range covers the measured number.
By their numbers in this assay, from the lowest: compounds 3, 1 and 2 (each within the scatter of the next).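

In this assay, a non-aromatic ring on the amide-type nitrogen gives a 1.4-fold lower number from compound 2 to compound 3 (0.16 log units; within the scatter) and a 1.4-fold lower number from compound 1 to compound 3 (0.16 log units; within the scatter), so cyclopropyl is not separated from pyridin-4-yl or pyridin-3-yl at this position. Across compounds 1, 2 and 3, neither swapping the aromatic ring for a non-aromatic one nor the smaller heavy-atom count of cyclopropyl moves the half-life beyond the scatter. Nothing available explains this result. On these data alone, whether a longer chain carrying an amine or a carboxylic acid on this nitrogen would move the half-life beyond the scatter stays open, as does the effect of changes elsewhere on the shared core.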